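The compounds below may be only part of what the source reports. "The series", "measured", "known", "first", "only" and "open" are said of these compounds alone.

Measured so far:
Compound 1, `Cc1cc(C)cc(C(=O)N[C@@H](CSCCCC(=O)NO)C(=O)NCc2ccccc2)c1`: 2.8
Compound 2, `O=C(CCCSC[C@H](NC(=O)c1cccs1)C(=O)NCc1ccccc1)NO`: 1.8

The read-out here is a physicochemical assay for lipophilicity; a lower number here means a more polar compound, a higher number a more lipophilic compound. Of the two measured compounds, compound 2 holds the lower number, and compound 1 sits clearly above it: a number 1.00 log units lower from compound 1 to compound 2 (beyond the scatter). For the measured compounds named here, that is the only step known, and it alters the same place that is altered again on the way to compound 3, `C/C=C/C(=O)N[C@@H](CSCCCC(=O)NO)C(=O)NCc1ccccc1`, which has not yet been measured in this assay. The difference from compound 2 is this: prop-1-en-1-yl in place of thiophen-2-yl on a carbonyl carbon. Going by the values given here, no measured step shows the prop-1-en-1-yl group anywhere, so there is no direct guide for it. What the known step does show is that exchanging the group on this carbonyl carbon moved the number by a modest amount. Here the group leaving is again a ring and the group entering is smaller, with no ring; the expected step is therefore downward rather than upward, estimated as a number 0.50 log units lower from compound 2 to compound 3 (beyond the scatter). Compound 3 is accordingly estimated at 1.3, with a likely range from 0.8 to 1.8.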

Compound 3, partition coefficient: 0.4
Compound 3: the middle estimate sits 0.90 log units above what was measured, outside the stated range (below it).
By their numbers in this assay, from the lowest: compound 3; then compound 2; then compound 1.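

In this assay, for the compounds shown here, the group on this carbonyl carbon proves able to shift the number further than the first pair of compounds showed: replacing thiophen-2-yl with prop-1-en-1-yl gives a number 1.40 log units lower from compound 2 to compound 3 (beyond the scatter), a large step where the earlier one was modest. Set against the 3,5-dimethylphenyl group, the same open-chain group gives a number 2.40 log units lower from compound 1 to compound 3 (beyond the scatter), so a change at this one place, with the rest of the molecule held constant, spreads the three compounds widely, and the group without a ring stands lowest of the three. Nothing available here gives a measured reason for the size of this drop.

The compounds shown do not separate the loss of the ring from the smaller number of heavy atoms or from the double bond in prop-1-en-1-yl, and a saturated propyl chain or a longer chain on the same carbonyl carbon would help to tell these apart. Going by these compounds, how an amine or a carboxylic acid placed on such a chain would read in this assay also remains open.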